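The source may report more compounds than this note shows. Statements on the series, on what has been measured and on what is new or still open speak of the compounds shown alone.

Measured so far:
- compound 1 `CN1CCN(CC2CCN(c3nccc4[nH]c(-c5ccc(F)c(F)c5)nc34)CC2)CC1`: 7400 nM
- compound 2 `CN1CCN(CC2CCN(c3nccc4[nH]c(-c5cc(F)cc(C(F)(F)F)c5)nc34)CC2)CC1`: 3100 nM

In an ADME assay on CHO cells (Cricetulus griseus) for cytotoxicity, read by MTT assay (on this read-out lower numbers stand for higher toxicity in this test and higher numbers for lower toxicity in this test), compound 2 holds the lower of the two numbers at 3100 nM, while compound 1 gives 7400 nM. The next compound is compound 3 `CN1CCN(CC2CCN(c3nccc4[nH]c(-c5cccc(C(=O)N(C)C)c5)nc34)CC2)CC1`, with the change (3-(dimethylcarbamoyl)phenyl in place of 3-fluoro-5-(trifluoromethyl)phenyl on an aromatic carbon). In words, 3-(dimethylcarbamoyl)phenyl takes the place of 3-fluoro-5-(trifluoromethyl)phenyl on an aromatic carbon between two ring nitrogen atoms.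

Among the measured compounds shown here, only one measured step bears on this place: a 2.4-fold lower number from compound 1 to compound 2 (0.38 log units; beyond the scatter). That step is modest but beyond the scatter, and it links two fluorinated aryl groups. No aryl group without fluorine and no amide-bearing group has been measured in this series, so the evidence is thin. The direction is therefore a tentative call. A return upward of about the same modest size is expected in this assay, with a step beyond the scatter far from certain.

The expected change is a 1.9-fold higher number from compound 2 to compound 3 (0.29 log units; within the scatter). For compound 3 the estimated value is 6000 nM, with an expected range of 2500 nM to 15000 nM.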

Compound 3, half-maximal cytotoxic concentration in the CHO assay: > 50000 nM
Compound 3: a limit, no number (the forecaster's own chance of this, stated with the estimate: 10%); middle value at least 8.3-fold (0.92 log units) from the limit.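

This position is far more sensitive in the CHO assay than the step between the two fluorinated aryl groups suggested: 3-(dimethylcarbamoyl)phenyl gives an at least 16-fold higher number from compound 2 to compound 3 (1.20 log units; beyond the scatter) and an at least 6.7-fold higher number from compound 1 to compound 3 (0.82 log units; beyond the scatter), both towards lower toxicity in this test. In the CHO assay compound 3 gives > 50000 nM, which is a limit of the assay and not a number, so these steps give only a minimum size, and the series has no measured ceiling for this change: the limit of > 50000 nM in the CHO assay, at which 1 of the 3 values shown sits.
In a physicochemical assay for solubility, read by HPLC, using the shake flask method, in phosphate buffer, with a stated time of 20 h, at pH 6.5 (on this read-out lower numbers stand for lower solubility and higher numbers for higher solubility), compound 2 gives 165000 nM and compound 3 gives 180000 nM, and the same change gives a 1.1-fold higher number from compound 2 to compound 3 (0.04 log units; within the scatter), so that read-out does not separate the two compounds, and the large step in cytotoxicity comes without a matching step in solubility.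

The change removes all fluorine and brings in the dimethylcarbamoyl group at once, so the compounds shown cannot assign the step to either the loss of the fluorinated substituents or the gain of the amide. Going by these compounds, an unsubstituted phenyl, a phenyl carrying a carboxylic acid or a phenyl carrying an aminomethyl group at this place would help to separate the two, and how far compound 3 lies beyond its limit stays open.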